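This account rests on a few compounds, and the source may have more. Where it says the series, first, only, none or still open, it means among the compounds named here.

Compounds measured so far:
compound 1 `Cc1ccc(CSc2cc(Cl)c(C)cc2S(=O)(=O)/N=C(\N)n2nc(C)cc2-c2ccccc2)cc1` — 89000 nM in a functional assay on MCF7 cells (Homo sapiens) for cytotoxicity, read by MTT assay, with a stated time of 72 h; a higher number here means a weaker inhibitor, a lower number a stronger inhibitor
compound 2 `Cc1cc(-c2ccccc2)n(/C(N)=N/S(=O)(=O)c2cc(C)c(Cl)cc2SCc2ccccc2C)n1` — 80000 nM in this assay
compound 3 `Cc1cc(-c2ccccc2)n(/C(N)=N/S(=O)(=O)c2cc(C)c(Cl)cc2SCc2ccc(Cl)cc2)n1` — 108000 nM in this assay

Compound 3 carries the highest number of the three, but the step from compound 1 to compound 3 a 1.2-fold higher number from compound 1 to compound 3 (0.08 log units; within the scatter) and the step from compound 2 to compound 3 a 1.4-fold higher number from compound 2 to compound 3 (0.13 log units; within the scatter) both lie within the scatter, so the three compounds are not separated by these data.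

Compound 4 `Cc1cc(-c2ccccc2)n(/C(N)=N/S(=O)(=O)c2cc(C)c(Cl)cc2SCc2ccccc2Cl)n1` differs from compound 3 by 2-chlorophenyl in place of 4-chlorophenyl on a saturated chain carbon bound to a sulfur. Two measured steps change the same phenyl ring on the saturated chain carbon bound to a sulfur: the step from compound 1 to compound 2 a 1.1-fold lower number from compound 1 to compound 2 (0.05 log units; within the scatter) moves a methyl from the 4-position to the 2-position of that ring, and the step from compound 2 to compound 3 a 1.4-fold higher number from compound 2 to compound 3 (0.13 log units; within the scatter) swaps a 2-methylphenyl for a 4-chlorophenyl. Neither step rises above the scatter. Moving a chloro from the 4-position to the 2-position is therefore expected to give no step beyond the scatter in this assay, with the number for compound 4 expected close to that of compound 3 a 1.1-fold lower number from compound 3 to compound 4 (0.06 log units; within the scatter).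

Compound 4 is estimated at 95000 nM, with a range from 50000 nM to 180000 nM.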

Compound 4, half-maximal inhibitory concentration: 135000 nM
Compound 4: the middle estimate sits 1.4-fold (0.15 log units) below what was measured; the measured number falls inside the stated range.
By their numbers in this assay, from the lowest: compounds 2, 1, 3 and 4 (each within the scatter of the next).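

Moving the chloro from the 4-chlorophenyl to the 2-chlorophenyl on a saturated chain carbon bound to a sulfur gives a 1.3-fold higher number from compound 3 to compound 4 (0.10 log units; within the scatter) in this assay, so a chloro pair now joins the methyl pair at this place, and neither pair separates. The two other new steps, a 1.5-fold higher number from compound 1 to compound 4 (0.18 log units; within the scatter) and a 1.7-fold higher number from compound 2 to compound 4 (0.23 log units; within the scatter), also stay within the scatter, which leaves the four compounds unseparated by any change made at this phenyl ring. Chloro in place of methyl on an aromatic carbon can now be read twice, and the two readings agree: the same change on two cores in this assay, a 1.2-fold higher number (0.08 log units; within the scatter) from compound 1 to compound 3 and a 1.7-fold higher number (0.23 log units; within the scatter) from compound 2 to compound 4, 1.4-fold (0.14 log units) apart, within the scatter of two such steps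

The compounds shown leave open whether an amine or a carboxylic acid on this phenyl ring, or a longer chain in place of the benzyl group, would give a step beyond the scatter. They also leave the rest of the shared core unread, since all four compounds carry it unchanged.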